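This account rests on a few compounds, and the source may have more. Where it says the series, first, only, none or still open, it means among the compounds named here.

Compound 1 `Nc1ccccc1/C=C/c1ccc(O)cc1` gives 79 ug/mL in a functional assay on MCF7 cells (Homo sapiens) for inhibition, read by MTT assay, with a stated time of 2 days; a lower number here means a stronger inhibitor, a higher number a weaker inhibitor.
Compound 2 `COc1ccc(/C=C/c2ccccc2O)cc1` gives 17 ug/mL in this assay.
Compound 3 `Nc1ccc(/C=C/c2ccccc2O)cc1` gives 23 ug/mL in this assay.

Compound 1 has the highest number of the three in this assay; compound 3 is nearest to it and compound 2 furthest, and both gaps lie beyond the scatter. Compound 3 and compound 2 differ in one place, (methoxy in place of amino on an aromatic carbon), and that change made a step of a 1.4-fold lower number from compound 3 to compound 2 (0.13 log units; within the scatter). Compound 4 `COc1ccccc1/C=C/c1ccc(O)cc1` is not yet measured. It differs from compound 1 by methoxy in place of amino on an aromatic carbon. Among the measured compounds shown here, this is the same kind of change as the one from compound 3 to compound 2, but not the same: in compound 4 the methoxy stands ortho to a group of 9 heavy atoms, whereas in compound 2 it stands para to a group of 9 heavy atoms. How the core of compound 1 differs from the core of compound 3 is not broken down here. Resting on that single measured pair alone, and because a 1.4-fold lower number from compound 3 to compound 2 (0.13 log units; within the scatter) stayed within the scatter, the expected step is a 1.4-fold lower number from compound 1 to compound 4 (0.16 log units; within the scatter). Compound 4 is therefore estimated at 55 ug/mL in this assay, with a range from 25 ug/mL to 120 ug/mL.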

Compound 4, half-maximal inhibitory concentration: 19 ug/mL
Beside the measured number, compound 4's estimate is 2.9-fold (0.46 log units) above it; measured number outside the range, below it.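

In this assay the exchange of amino for methoxy on the core of compound 1 made a step of a 4.2-fold lower number from compound 1 to compound 4 (0.62 log units; beyond the scatter), so on this core the change counts for more than it did on the core of compound 3. The two steps do not agree in size, and the change cannot be carried from one core to the other at a fixed value: the same change on two cores in this assay, a 1.4-fold lower number (0.13 log units; within the scatter) from compound 3 to compound 2 and a 4.2-fold lower number (0.62 log units; beyond the scatter) from compound 1 to compound 4, 3.1-fold (0.49 log units) apart, beyond the scatter of two such steps
Among the compounds shown here, only two pairs stand behind this comparison, and they also differ in where the methoxy sits on its ring, so they do not show whether the core or that placement sets the size of the step.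

The compounds shown leave open how other groups at this place on the core of compound 1, such as ethoxy, a chlorine atom or a dimethylamino group, would compare with methoxy. They also leave open whether the same exchange on a third core would fall nearer to one step or to the other.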